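The source may report more compounds than this note shows. Statements on the series, on what has been measured and on what is new or still open speak of the compounds shown alone.

Of the compounds shown here, two have been tested in a functional assay on HeLa S3 cells (Homo sapiens) for antiproliferative activity, read by XTT assay, with a stated time of 72 h; a lower number here means a stronger inhibitor, a higher number a weaker inhibitor. Compound 1 `CNc1ncnc2c1c(-c1cccs1)cn2[C@@H]1O[C@H](CO)[C@@H](O)[C@H]1O` gave only a limit, > 20000 nM. Compound 2 `Cc1nc(N)c2c(-c3ccoc3)cn([C@@H]3O[C@H](CO)[C@@H](O)[C@H]3O)c2n1` also gave only a limit, > 20000 nM. No number therefore fixes where compound 2 stands, and both compounds sit at the same ceiling (the limit of > 20000 nM in this assay, at which 2 of the 2 values shown sit). Compound 3 `C#Cc1cn([C@@H]2O[C@H](CO)[C@@H](O)[C@H]2O)c2nc(C)nc(N)c12` differs from compound 2 in one place, with ethynyl in place of furan-3-yl on an aromatic carbon. Going by the values given here, no measured step covers this exchange, so the expectation is loose. In this assay a modest gain in potency is expected, though compound 3 may well stay at the limit too. The expected change is an at least 2.0-fold lower number from compound 2 to compound 3 (0.30 log units; that floor lies within the scatter). For compound 3 the estimate is 10000 nM, with an expected range from 1500 nM to 20000 nM.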

Compound 3, half-maximal inhibitory concentration: > 20000 nM
Compound 3: a limit, no number; the forecaster's own chance of this, stated with the estimate: 60%; middle value at least 2.0-fold (0.30 log units) from the limit.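

Compound 3 gives only a limit, > 20000 nM, as compound 2 does, so the exchange of furan-3-yl for ethynyl between compound 2 and compound 3 cannot be read. The compounds shown leave open how strongly any of them inhibits, because all stop at one ceiling: the limit of > 20000 nM in this assay, at which 3 of the 3 values shown sit.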